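Trifluoromethyl in place of cyano on the phenoxy ring

The source may report more compounds than this note shows. Statements on the series, on what has been measured and on what is new or still open speak of the compounds shown alone.

Of the compounds shown here, three sharing one core have been measured in an ADME assay on MDCK cells (Canis lupus familiaris) for permeability; a lower number here means that the compound crosses the layer more slowly, a higher number that the compound crosses the layer faster. Compound 1 `CCS(=O)(=O)Nc1ccc(Oc2ccccc2)c(-c2cn(C)c(=O)c3[nH]ccc23)c1` gives 22 10^-6 cm/s. Compound 2 `Cn1cc(-c2cc(S(N)(=O)=O)ccc2Oc2ccccc2)c2cc[nH]c2c1=O` carries a sulfamoyl group where compound 1 carries an (ethylsulfonyl)amino group. In this assay compound 2 gives 22 10^-6 cm/s. Compound 3 `CCS(=O)(=O)Nc1ccc(Oc2ccc(C#N)cc2)c(-c2cn(C)c(=O)c3[nH]ccc23)c1`, which carries a cyano group on the phenoxy ring, gives 11 10^-6 cm/s in this assay, the lowest of the three numbers, though it sits within the scatter of both compound 1 and compound 2.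

Compound 4 `CCS(=O)(=O)Nc1ccc(Oc2ccc(C(F)(F)F)cc2)c(-c2cn(C)c(=O)c3[nH]ccc23)c1` has not yet been measured in this assay. Its change from compound 3 is trifluoromethyl in place of cyano on an aromatic carbon: the trifluoromethyl group sits on a six-membered aromatic ring of carbon only, para to a large group. Among the compounds with values here, no measured step puts a trifluoromethyl group anywhere. The step that touches the same ring position is a 2.0-fold lower number from compound 1 to compound 3 (0.30 log units; within the scatter), where the cyano group entered. The other step, no change at the digits printed from compound 1 to compound 2 (within the scatter), concerns a different part of the molecule. With only these steps to lean on, the step of a 1.4-fold higher number from compound 3 to compound 4 (0.13 log units; within the scatter) is expected to remain within the scatter. Compound 4 is therefore estimated at 15 10^-6 cm/s in this assay, with a range from 7 10^-6 cm/s to 30 10^-6 cm/s.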

Compound 4, apparent permeability: 11 10^-6 cm/s
The estimate for compound 4 lay 1.4-fold (0.13 log units) above the measured number, within the range that was stated.
By their numbers in this assay, from the lowest: compounds 3, 4, 1 and 2 (each within the scatter of the next).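

In this assay the cyano group gives way to trifluoromethyl on the aromatic carbon para to a large group, with no change at the digits printed from compound 3 to compound 4 (within the scatter), so this position now tolerates an exchange that removes a triple bond and the 1 hydrogen-bond acceptor of the cyano group without any step beyond the scatter. Set against the hydrogen of compound 1, the new group gives a 2.0-fold lower number from compound 1 to compound 4 (0.30 log units; within the scatter), the same size as a 2.0-fold lower number from compound 1 to compound 3 (0.30 log units; within the scatter), so both substituents at this place stand at the same distance from the unsubstituted ring and that distance remains within the scatter. No measurement accompanies these numbers that could explain them.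

On these data alone, whether the position stays this flat with an amine, a carboxylic acid or a longer chain in the same place remains open, since the two groups seen here both carry no hydrogen-bond donor and no net charge. Also open, as far as these compounds go, is whether trifluoromethyl or cyano on the phenoxy ring would give the same picture alongside the sulfamoyl group of compound 2.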